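Moving the chlorine on the benzamide of compound 3

A few compounds are considered here, and "the series" means these few. Any claim that something is new, unique, unknown or untested is made for them only; others in the source may bear on it.

Measured compounds in an assay on blood for inhibition of Indoleamine 2,3-dioxygenase 1 (Homo sapiens), read by mass spectrometry, with stated times of 4 h and 18 h; a lower number here means a stronger inhibitor, a higher number a weaker inhibitor:
- Compound 1, `C[C@@H](NCc1ccc(Cl)cc1)[C@H]1CC[C@@H](c2ccnc3ccc(F)cc32)CC1`: a limit, > 1000 nM
- Compound 2, `C[C@@H](NS(=O)(=O)c1ccc(Cl)cc1)[C@H]1CC[C@@H](c2ccnc3ccc(F)cc32)CC1`: 484 nM
- Compound 3, `C[C@@H](NC(=O)c1cccc(Cl)c1)[C@H]1CC[C@@H](c2ccnc3ccc(F)cc32)CC1`: 97 nM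

Compound 3 holds the lowest of the two numbers in this assay. Compound 2 is the nearest, and the step of a 5.0-fold lower number from compound 2 to compound 3 (0.70 log units; beyond the scatter) lies beyond the scatter. Compound 1 reports only a limit (the limit of > 1000 nM in this assay, at which 1 of the 3 values shown sits), so the step of an at least 10-fold lower number from compound 1 to compound 3 (1.01 log units; beyond the scatter) is a lower bound rather than a measured size, and the same holds for an at least 2.0-fold lower number from compound 1 to compound 2 (0.31 log units; beyond the scatter).

Compound 4, `C[C@@H](NC(=O)c1ccccc1Cl)[C@H]1CC[C@@H](c2ccnc3ccc(F)cc32)CC1`, differs from compound 3 in one place: 2-chlorophenyl in place of 3-chlorophenyl on a carbonyl carbon. The measured steps all concern the link between the amine nitrogen and the chlorophenyl ring, not where the chlorine sits on that ring, so none of them bears directly on this change. With nothing to point either way, the expected step is none beyond the scatter, with the estimate held near compound 3 and a wide range, written as a 1.5-fold higher number from compound 3 to compound 4 (0.19 log units; within the scatter). Compound 4 is therefore estimated to give 150 nM in this assay, expected to fall between 50 nM and 500 nM.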

Compound 4, half-maximal inhibitory concentration: 135 nM
For compound 4 the middle estimate is 1.1-fold (0.05 log units) above the measured one, and the stated range covers the measured number.
By their numbers in this assay, from the lowest: compounds 3 and 4 (each within the scatter of the next); then compound 2. At a limit, above all of these: compound 1.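

2-Chlorophenyl and 3-chlorophenyl on the carbonyl carbon cannot be told apart in this assay, with a 1.4-fold higher number from compound 3 to compound 4 (0.14 log units; within the scatter), so among the compounds shown this change in the chlorine's place has no readable effect. The gain of the carbonyl link over the sulfonyl link also holds with the 2-chlorophenyl ring, with a 3.6-fold lower number from compound 2 to compound 4 (0.55 log units; beyond the scatter), although this step changes the chlorine's place as well as the link. Compound 1 is reported only as a limit, so an at least 7.4-fold lower number from compound 1 to compound 4 (0.86 log units; beyond the scatter) gives a lower bound on that step rather than its size: the limit of > 1000 nM in this assay, at which 1 of the 4 values shown sits.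

The compounds shown leave open how an amide carrying 4-chlorophenyl would read, a comparison that would separate the link from the chlorine's place in the step from compound 2. They also leave open whether the ring needs a chlorine at all, a question that an unsubstituted phenyl, or a fluorine, a methoxy group or a nitrile in the chlorine's place, would address.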